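The source may report more compounds than this note shows. Statements on the series, on what has been measured and on what is new or still open speak of the compounds shown alone.

Measured compounds:
compound 1, `CC(C)/C(=C1\C(=O)NC(=O)N1C)c1ccc(-c2ccc3cccc(F)c3c2)[nH]c1=O`: 22500 nM
compound 2, `CC(C)C(/C=C1\NC(=O)NC1=O)c1ccc(-c2ccc3cccc(F)c3c2)[nH]c1=O`: 10700 nM

In a physicochemical assay for solubility, in phosphate buffer, measured as kinetic solubility (on this read-out lower numbers stand for lower solubility and higher numbers for higher solubility), compound 2 gives 10700 nM, the lowest of the two numbers. Compound 1 gives 22500 nM, and the gap between the two lies beyond the scatter of this assay. Compound 3, `CC(C)C(CC1C(=O)NC(=O)N1C)c1ccc(-c2ccc3cccc(F)c3c2)[nH]c1=O`, has not yet been measured. It differs from compound 2 in one place: a group of 9 heavy atoms (5 carbon, 2 nitrogen, 2 oxygen; one five-membered non-aromatic ring with 2 hetero atoms) in place of a group of 8 heavy atoms (4 carbon, 2 nitrogen, 2 oxygen; one five-membered non-aromatic ring with 2 hetero atoms), on a saturated chain carbon bound to an aromatic carbon and a saturated chain carbon. Among the compounds with values here, no step between measured compounds covers this change, so the expectation rests on the two numbers alone and on the size of the change, which touches a single group while the shared core stays the same. A modest rise in this assay is expected, of about a 1.9-fold higher number from compound 2 to compound 3 (0.27 log units; within the scatter), which may or may not exceed the scatter. Compound 3 is estimated at 20000 nM in this assay, with a range from 8000 nM to 50000 nM.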

Compound 3, solubility: 33600 nM
For compound 3 the middle estimate is 1.7-fold (0.23 log units) below the measured one, within the range that was stated.
By their numbers in this assay, from the lowest: compound 2; then compounds 1 and 3 (each within the scatter of the next).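

In this assay, within the data shown here, the exchange on the saturated chain carbon bound to an aromatic carbon and a saturated chain carbon gives a step of a 3.1-fold higher number from compound 2 to compound 3 (0.50 log units; beyond the scatter) and so provides the first reading of a single change at this position. With the shared core unchanged, the read-out responds to the group placed here, and the (3-methyl-2,5-dioxoimidazolidin-4-yl)methyl group, with 2 double bonds outside aromatic rings and 1 hydrogen-bond donor, goes with the higher number. No measurement shown bears on what lies behind this step.

The entering group differs from the leaving group in both its methyl and its double bonds, and the compounds shown do not separate these two differences. As far as these compounds go, how a carboxylic acid or an amine would read at this position also remains open.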